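Swapping Difluorophenyl for Chlorophenyl on the Ring Nitrogen

The compounds below may be only part of what the source reports. "The series", "measured", "known", "first", "only" and "open" are said of these compounds alone.

Measured in a functional assay on CHO cells with adenosine receptor A1 (Homo sapiens) as the target, read by cAMP accumulation and immunoassay, with a stated time of 6 min, tested at 1 uM; on this read-out lower numbers stand for a stronger effect and higher numbers for a weaker effect at the one concentration tested:
Compound 1 `Nc1scc(CN2CCN(C3CCCCCC3)CC2)c1C(=O)c1ccc(Cl)cc1` gives 3.7%.
Compound 2 `Nc1scc(CN2CCN(c3ccc(F)c(F)c3)CC2)c1C(=O)c1ccc(Cl)cc1` gives -78%.
Compound 3 `Nc1scc(CN2CCN(c3cc(F)ccc3F)CC2)c1C(=O)c1ccc(Cl)cc1` gives -59%.

Among these three numbers compound 3 stands second highest; its nearest neighbour is compound 2, beyond the scatter, and compound 1 lies furthest away. Compound 4 `Nc1scc(CN2CCN(c3ccccc3Cl)CC2)c1C(=O)c1ccc(Cl)cc1` differs from compound 3 by 2-chlorophenyl in place of 2,5-difluorophenyl on an amine nitrogen in a ring. Among the measured compounds shown here, the steps that bear on this change are a number 81.7 percentage points lower from compound 1 to compound 2 (beyond the scatter) and a number 62.7 percentage points lower from compound 1 to compound 3 (beyond the scatter), both large when cycloheptyl gave way to a difluorophenyl, and a number 19 percentage points higher from compound 2 to compound 3 (beyond the scatter), a modest step between two difluorophenyl groups. The change to compound 4 again swaps one such group for another, so only a modest step in this assay, or none beyond the scatter, is expected. For compound 4 the estimate is -60%, between -85% and -25%. This estimate means an expected step of a number 1 percentage points lower from compound 3 to compound 4 (within the scatter).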

Compound 4, a percentage reported as activity, at one concentration (the size of the read-out at that concentration, not a potency): -5.2%
Compound 4: middle estimate off by 54.8 percentage points, on the low side; measured number outside the range, above it.
By their numbers in this assay, from the lowest: compound 2; then compound 3; then compounds 4 and 1 (each within the scatter of the next).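

On the amine nitrogen in a ring, a phenyl group carrying halogen does not by itself give a strongly negative number: in this assay 2-chlorophenyl brings a number 53.8 percentage points higher from compound 3 to compound 4 (beyond the scatter) and a number 72.8 percentage points higher from compound 2 to compound 4 (beyond the scatter). The choice of halogen substitution on this ring therefore matters far more than the two difluorophenyl compounds alone showed. The change also leaves a number 8.9 percentage points lower from compound 1 to compound 4 (within the scatter), so this aromatic group reads like cycloheptyl here.

No evidence given here explains these gaps. An unsubstituted phenyl, 2-fluorophenyl or 2,5-dichlorophenyl group could show whether the halogen's identity or its placement separates these compounds.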